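This account rests on a few compounds, and the source may have more. Where it says the series, first, only, none or still open, it means among the compounds named here.

Measured so far:
- compound 1, `Cc1cccc(Oc2ccnc(N3CCC[C@H]3C(=O)NCc3cccnc3)n2)c1`: 6%
- compound 2, `COC[C@@H]1CCCN1C(=O)C1CCCN1c1cc(Nc2cccc(Br)c2)ncn1`: 0%
- compound 3, `Cc1cccc(Oc2ccnc(N3CCC[C@H]3C(=O)NCCCn3ccnc3)n2)c1`: 2%

In an assay on isolated protein for inhibition of tyrosine-protein kinase ZAP-70 (Homo sapiens), read by HTRF, tested at 10 uM (a lower number here means less inhibition, a higher number more inhibition at the concentration tested (going by the name of the read-out)), compound 3 gives 2%, the second highest of the three numbers, but all three sit close together. Compound 2 gives 0%, within the scatter of compound 3. Compound 1 gives 6%, also within the scatter of compound 3. Among the measured compounds shown here, the one step measured inside the series, a number 4 percentage points lower from compound 1 to compound 3 (within the scatter), is within the scatter, so swapping the group on the amide-type nitrogen has so far not moved the read-out.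

Compound 4 is `COC(=O)C(CO)NC(=O)[C@@H]1CCCN1c1nccc(Oc2cccc(C)c2)n1`. The change from compound 3 is 2-hydroxy-1-(methoxycarbonyl)ethyl in place of 3-(1H-imidazol-1-yl)propyl on an amide-type nitrogen. The step that bears on it is a number 4 percentage points lower from compound 1 to compound 3 (within the scatter), since that step also replaced the group on the amide-type nitrogen and stayed within the scatter. Nothing measured suggests that a third variation at this nitrogen would behave differently; a step of no more than the scatter is expected in this assay, with no direction favoured.

Compound 4 is therefore estimated at 3%, with a range from 0% to 12%. The expected step is a number 1 percentage points higher from compound 3 to compound 4 (within the scatter).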

Compound 4, a percentage reported as inhibition, at one concentration (the size of the read-out at that concentration, not a potency): 0%
Beside the measured number, compound 4's estimate is 3 percentage points above it; the measured number falls inside the stated range.
By their numbers in this assay, from the lowest: compounds 2, 4, 3 and 1 (each within the scatter of the next).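

Across this assay, the step of a number 2 percentage points lower from compound 3 to compound 4 (within the scatter) and the step of a number 6 percentage points lower from compound 1 to compound 4 (within the scatter) extend the variation on the amide-type nitrogen to a group of a different kind: 2-hydroxy-1-(methoxycarbonyl)ethyl has no ring, whereas 3-(1H-imidazol-1-yl)propyl and (pyridin-3-yl)methyl each carry an aromatic ring. With both steps within the scatter, this position now shows no measurable separation among ring-bearing and ring-free groups at the single concentration tested, so an aromatic ring in this group is not seen to matter in this assay. No measurement available here offers an explanation for this flat result.

Since compound 1, compound 3 and compound 4 all sit within the scatter of one another, the data cannot show whether any group at this nitrogen would lift the read-out clear of that scatter. Open cases are a free carboxylic acid in place of the methyl ester, a piperidine or primary amine on the chain, and a longer chain carrying the hydroxy group.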